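This account rests on a few compounds, and the source may have more. Where it says the series, first, only, none or still open, it means among the compounds named here.

Measured in a functional assay (spleen, spleen) for activation, with Mus musculus as the target; a higher number here means that more compound is needed for the effect, a lower number that less compound is needed:
compound 1, `CCSc1nc(N)c2nc(O)n(Cc3ccccc3)c2n1`: 0.1 uM
compound 2, `Nc1ncnc2c1nc(O)n2Cc1cccc2ccccc12`: 10 uM

Compound 1 holds the lowest of the two numbers in this assay; its nearest neighbour is compound 2, whose number is higher by a margin that lies well beyond the scatter. For the measured compounds named here, the two measured compounds differ in more than one place, so no single-change step has been measured.

Compound 3, `CCCOc1nc(N)c2nc(O)n(Cc3ccccc3)c2n1`, is not yet measured. It differs from compound 1 in one place: propoxy in place of ethylsulfanyl on an aromatic carbon. Going by the values given here, with no measured step to lean on, the expectation rests on compound 1 alone and on the modest size of the change. In this assay the expected step is a 3.0-fold higher number from compound 1 to compound 3 (0.48 log units; beyond the scatter), a small move toward a higher number that may well sit within the scatter. Compound 3 is therefore estimated at 0.3 uM, with a range of 0.05 uM to 2 uM.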

Compound 3, minimum effective concentration: 0.01 uM
Beside the measured number, compound 3's estimate is 30-fold (1.48 log units) above it; the whole stated range lies above it.
By their numbers in this assay, from the lowest: compound 3; then compound 1; then compound 2.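

In this assay, the aromatic carbon between two ring nitrogen atoms proves to be a position where a single change moves the number well beyond the scatter: propoxy in place of ethylsulfanyl gives a 10-fold lower number from compound 1 to compound 3 (1.00 log units; beyond the scatter). For the compounds shown here, this is the first single-change step, and it shows that ethylsulfanyl is not required at this position for a low number. The change replaces sulfur with oxygen and also adds one carbon to the chain, so this one step cannot separate the two differences, and nothing at hand explains the shift.

Ethoxy and propylsulfanyl at this carbon would separate the atom change from the chain change. Going by these compounds, it also remains open how a longer chain such as butoxy, or an amine such as propylamino, would read here.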